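The source may hold more compounds than are shown below. What is called first, only, known or untested is meant among the compounds shown, and "the series" means these compounds.

Compound 1 `NCCCCCOc1ccc([C@H]2CC[C@]3(CC2)OOC2(O3)C3CC4CC(C3)CC2C4)cc1`: < 7 mL.min-1.g-1
Compound 2 `c1cc([C@H]2CC[C@]3(CC2)OOC2(O3)C3CC4CC(C3)CC2C4)ccc1OCCOC1CCNCC1`: < 7 mL.min-1.g-1
Compound 3 `CC(C)(O)CN1CCC(Oc2ccc([C@H]3CC[C@]4(CC3)OOC3(O4)C4CC5CC(C4)CC3C5)cc2)CC1`: 18 mL.min-1.g-1

All three share one core and differ only in the group on the aromatic oxygen. In an ADME assay on microsomes from liver (Homo sapiens) for metabolic stability, read by LC-MS, tested at 1 uM (a lower number here means slower removal, a higher number faster removal of the compound), compound 1 gives < 7 mL.min-1.g-1, which is a limit of the assay rather than a number. Compound 2 likewise sits at a limit, < 7 mL.min-1.g-1. Compound 3 gives 18 mL.min-1.g-1. Compound 4 `c1cc([C@H]2CC[C@]3(CC2)OOC2(O3)C3CC4CC(C3)CC2C4)ccc1OCCC1CCNCC1` is not yet measured; it differs from compound 1 in that (piperidin-4-yl in place of 3-aminopropyl on a saturated chain carbon, two bonds along the chain from an oxygen on an aromatic ring). Within the data shown here, two measured steps bear on this change. a step that the two limits leave unreadable from compound 1 to compound 2. an at least 2.5-fold higher number from compound 1 to compound 3 (0.41 log units; beyond the scatter). The closest comparison, compound 2, stays at the limit of < 7 mL.min-1.g-1 in this assay, at which 2 of the 3 values shown sit. Compound 4 is therefore expected to show no step beyond the scatter, a step that the limit leaves unreadable from compound 1 to compound 4. The estimate for compound 4 is 6 mL.min-1.g-1, between 3 mL.min-1.g-1 and 13 mL.min-1.g-1.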

Compound 4, intrinsic clearance in microsomes: < 7 mL.min-1.g-1
Compound 4 gave a limit, no number; the forecaster's own chance of this, stated with the estimate: 65%; the middle value is on the limit's open side.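

In this assay compound 4 gives < 7 mL.min-1.g-1, which is a limit of the assay and not a number. So a piperidin-4-yl ring in place of 3-aminopropyl keeps this position at the limit, and the steps from compound 4 to compound 1 and compound 2 cannot be read. The move from the substituted ring of compound 3 does register, as an at least 2.5-fold lower number from compound 3 to compound 4 (0.41 log units; beyond the scatter).

On these data alone, compound 3 changes both the ring's attachment and its nitrogen substituent, so their shares stay unknown. A methyl group on the ring nitrogen of compound 4 would help separate them.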